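Trifluoromethyl Addition on Two Related Cores

The source may hold more compounds than are shown below. What is called first, only, known or untested is meant among the compounds shown, and "the series" means these compounds.

Measured compounds:
- compound 1 `C=C(Br)C(=O)Nc1ccc(/C=C2\SC(=O)N(Cc3ccccc3)C2=O)cc1`: 2300 nM
- compound 2 `C=C(Br)C(=O)Nc1ccc(/C=C2\SC(=O)N(Cc3ccc(C(F)(F)F)cc3)C2=O)cc1`: 8000 nM
- compound 3 `Nc1cccc(/C=C2\SC(=O)N(Cc3ccccc3)C2=O)c1`: > 250000 nM

All three were tested in a functional assay on CCRF-CEM cells (Homo sapiens) for cytotoxicity, read by cell counting, with a stated time of 3 days; on this read-out lower numbers stand for stronger inhibition and higher numbers for weaker inhibition. Compound 1 and compound 2 share one core and differ in a single place: trifluoromethyl in place of hydrogen on an aromatic carbon. That change gave a 3.5-fold higher number from compound 1 to compound 2 (0.54 log units; beyond the scatter), so on this core the added trifluoromethyl weakened the effect a little.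

Compound 3 is built on a different core, and the difference between the two cores is not broken down here. For compound 3 this assay reports only a limit, not a number, at the limit of > 250000 nM in this assay, at which 1 of the 3 values shown sits.

Compound 4 `Nc1cccc(/C=C2\SC(=O)N(Cc3ccc(C(F)(F)F)cc3)C2=O)c1` has not yet been measured. It differs from compound 3 by trifluoromethyl in place of hydrogen on an aromatic carbon. The place of the change is described in the same words as for the step from compound 1 to compound 2, so it is the same change, now made on the core of compound 3.

Compound 3 is expected to stay at the limit or move to a higher number, because the same change gave a 3.5-fold higher number from compound 1 to compound 2 (0.54 log units; beyond the scatter) on the other core and because compound 3 already reads > 250000 nM. The step from compound 3 to compound 4 is therefore estimated as a step that the limit leaves unreadable from compound 3 to compound 4. Compound 4 is expected to give about 400000 nM in this assay, most likely again as a limit rather than a number, with a range estimated between 150000 nM and 1200000 nM.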

Compound 4, half-maximal inhibitory concentration: > 250000 nM
Compound 4: a limit, no number; the forecaster's own chance of this, stated with the estimate: 85%; the middle value does not contradict the limit.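

Compound 4 reads > 250000 nM as a limit, not a number. Compound 3 reads > 250000 nM as a limit too, so no size can be read for the step from compound 3 to compound 4. The compounds shown leave open whether trifluoromethyl in place of hydrogen on an aromatic carbon changes the reading on the core of compound 3 as it did on the core of compound 1.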